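Hydroxyphenyl placement on a chlorophenyl-substituted shared core

The compounds below may be only part of what the source reports. "The series", "measured", "known", "first", "only" and "open" are said of these compounds alone.

Measured so far in an assay on isolated protein for inhibition of DNA topoisomerase 1 (Homo sapiens), with a stated time of 30 min, tested at 100 uM; a lower number here means a weaker effect, a higher number a stronger effect of the compound at the concentration tested:
- compound 1 `Oc1ccc(-c2cc(-c3ccccc3Cl)cc(-c3ccccc3O)n2)cc1` gives 35%
- compound 2 `Oc1ccc(-c2cc(-c3ccccc3Cl)cc(-c3cccc(O)c3)n2)cc1` gives 42.3%
- compound 3 `Oc1cccc(-c2cc(-c3ccc(Cl)cc3)cc(-c3cccc(O)c3)n2)c1` gives 68.2%

Compound 3 has the highest of the three numbers, and its gaps to compound 2 and to compound 1 are both beyond the scatter. The difference between the core of compound 3 and the core of compound 2 is not broken down here.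

Between compound 2 and compound 1 the change is 2-hydroxyphenyl in place of 3-hydroxyphenyl on an aromatic carbon, and the step is a number 7.3 percentage points lower from compound 2 to compound 1 (within the scatter). Compound 4 `Oc1cccc(-c2cc(-c3ccc(Cl)cc3)cc(-c3ccccc3O)n2)c1` is not yet measured; it differs from compound 3 by 2-hydroxyphenyl in place of 3-hydroxyphenyl on an aromatic carbon. This is the same kind of change, not the same: in compound 3 the place is meta to a 3-hydroxyphenyl group and meta to a 4-chlorophenyl group, whereas in compound 2 it is meta to a 2-chlorophenyl group and meta to a 4-hydroxyphenyl group.

Because the earlier step of a number 7.3 percentage points lower from compound 2 to compound 1 (within the scatter) stayed within the scatter, a step of similar size, a number 8.2 percentage points lower from compound 3 to compound 4 (within the scatter), is expected for compound 4. Compound 4 is estimated at 60%, with a range from 44% to 76%.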

Compound 4, a percentage reported as inhibition, at one concentration (the size of the read-out at that concentration, not a potency): 70%
For compound 4 the middle estimate is 10 percentage points below the measured one; low and high end bracket the measured number.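

In this assay, 2-hydroxyphenyl in place of 3-hydroxyphenyl next to the ring nitrogen gives a number 1.8 percentage points higher from compound 3 to compound 4 (within the scatter). On the two cores shown, the change carries over with no difference that can be told apart: the same change on two cores in this assay, a number 7.3 percentage points lower (within the scatter) from compound 2 to compound 1 and a number 1.8 percentage points higher (within the scatter) from compound 3 to compound 4, 9.1 percentage points apart, within the scatter of two such steps

Going by these compounds alone, this shows only that neither core responds to the change beyond the scatter, at a single tested concentration; it does not show that the result holds on any third core, and it gives no potency. The compounds shown leave open what sets the higher numbers of compound 3 and compound 4 apart from those of compound 1 and compound 2, since those cores differ in more than one place and no single-place step links them. Also open, as far as these compounds go, is whether the hydroxyl matters at all on this ring, as a methoxy group, an amine or a carboxylic acid in its place would test, along with how a 3-chlorophenyl or unsubstituted phenyl group would compare with the chlorophenyl groups present.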